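Working notes: diethylamino to amino

This account rests on a few compounds, and the source may have more. Where it says the series, first, only, none or still open, it means among the compounds named here.

Measured so far in a functional assay on PC-3 cells (Homo sapiens) for antiproliferative activity, read by MTT assay, with a stated time of 48 h; a lower number here means a stronger inhibitor, a higher number a weaker inhibitor:
- compound 1 `CCn1c(C(=O)NCCN(C)C)ccc1C(CC)(CC)c1ccc(OCCC(O)(CC)CC)c(C)c1` gives 870 nM
- compound 2 `CCN(CC)CCNC(=O)c1ccc(C(CC)(CC)c2ccc(OCCC(O)(CC)CC)c(C)c2)n1CC` gives 3350 nM

Among the measured compounds shown here, of the two measured compounds, compound 2 carries the higher number, and compound 1 is its only neighbour. Compound 3 `CCn1c(C(=O)NCCN)ccc1C(CC)(CC)c1ccc(OCCC(O)(CC)CC)c(C)c1` is still unmeasured. The change is amino in place of diethylamino on a saturated chain carbon, two bonds along the chain from an amide-type nitrogen and puts amino in place of diethylamino on a saturated chain carbon, two bonds along the chain from an amide-type nitrogen. For the measured compounds named here, only one measured step bears on it, and that step is modest and beyond the scatter. Since a 3.9-fold higher number from compound 1 to compound 2 (0.59 log units; beyond the scatter) came with diethylamino in place of dimethylamino on that same carbon, a move of similar size towards a lower number is expected in this assay for now. Going by the values given here, no compound with the amino group has been measured, so this expectation is loose. The estimated step is a 2.8-fold lower number from compound 2 to compound 3 (0.45 log units; beyond the scatter) on this single precedent. Compound 3 is expected at 1200 nM with an estimated range of 350 nM to 4500 nM for the measurement.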

Compound 3, half-maximal inhibitory concentration: 2420 nM
The estimate for compound 3 lay 2.0-fold (0.30 log units) below the measured number, within the range that was stated.
By their numbers in this assay, from the lowest: compound 1; then compounds 3 and 2 (each within the scatter of the next).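

On the saturated chain carbon, two bonds along the chain from an amide-type nitrogen, amino in place of diethylamino gives a 1.4-fold lower number from compound 2 to compound 3 (0.14 log units; within the scatter) in this assay and so leaves these two groups unseparated. Amino in place of dimethylamino gives a 2.8-fold higher number from compound 1 to compound 3 (0.44 log units; beyond the scatter) in the same read-out, which sets dimethylamino in compound 1 apart from both other groups, so the numbers do not run in one direction from amino through dimethylamino to diethylamino. Nothing at hand bears on why the dimethylamino compound stands apart.

From the compounds shown here alone, whether a methylamino group on this carbon would sit with compound 1 or with compounds 2 and 3 remains open. Also open, going by these compounds, is whether a longer chain between the amide-type nitrogen and the amine keeps dimethylamino apart from amino and diethylamino.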